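Fluoro on the pendant phenyl of the quinoline analogue

The compounds below may be only part of what the source reports. "The series", "measured", "known", "first", "only" and "open" are said of these compounds alone.

Going by the values given here, compound 1 `O=C1COc2ccc(-c3cnc(Cl)c(NS(=O)(=O)c4ccc(F)cc4)c3)cc2N1c1ccccc1` is the one member of this pair with a number: in a functional assay on A549 cells (Homo sapiens) for antiproliferative activity, read by MTT assay, with a stated time of 72 h (a lower number here means a stronger inhibitor, a higher number a weaker inhibitor), compound 1 gives 14700 nM. Compound 2 `O=C1COc2ccc(-c3cnc4ccccc4c3)cc2N1c1ccccc1` reaches only a limit, and in this assay compound 2 gives > 40000 nM. Among the compounds with values here, that limit is where compound 2 stands, as the limit of > 40000 nM in this assay, at which 1 of the 2 values shown sits, records; no number is available for it, so no measured step within the set can be computed. Compound 3 `O=C1COc2ccc(-c3cnc4ccccc4c3)cc2N1c1ccc(F)cc1` is the next analogue of compound 2, not yet measured in this assay. The change from compound 2 to compound 3 is fluoro in place of hydrogen on an aromatic carbon. With compound 2 already at the limit, the step from compound 2 to compound 3 in this assay is expected to be a step that the limit leaves unreadable from compound 2 to compound 3, that is, nothing beyond the scatter. Compound 3 is therefore estimated to give 45000 nM in this assay, within a range of 20000 nM to 100000 nM, with a fair chance that only a limit is reported.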

Compound 3, half-maximal inhibitory concentration: > 40000 nM
Compound 3: no number, only a limit; the forecaster's own chance of this, stated with the estimate: 70%; the middle value is on the limit's open side.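

Compound 2 and compound 3 both stop at a limit, so no step can be read between them: the limit of > 40000 nM in this assay, at which 2 of the 3 values shown sit.

The compounds shown leave open whether going from phenyl to 4-fluorophenyl changes antiproliferative activity at all, as neither compound has a number.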